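The compounds below may be only part of what the source reports. "The series", "measured", "known", "first", "only" and "open" are said of these compounds alone.

Working notes on the series in an assay on isolated protein for inhibition of ATP-dependent RNA helicase SUPV3L1, mitochondrial (Homo sapiens); a higher number here means a weaker inhibitor, a lower number a stronger inhibitor.

The series shares a core carrying a long alkylamino chain. Compound 1 `CCCCCCCCCCCCNc1nc(O)c2ncnc-2c(O)n1` carries no substituent on the ring nitrogen. Compound 2 `CCCCCCCCCCCCNc1nc(=O)c2c(ncn2[C@@H]2C[C@H](O)[C@@H](CO)O2)c(=O)[nH]1` and compound 3 `CCCCCCCCCCCCCCNc1nc(=O)c2ncn([C@@H]3O[C@H](CO)[C@@H](O)[C@H]3O)c2c(=O)[nH]1` carry sugar groups there. Compound 4 `CCCCCCCCCCCCNc1nc(=O)c2c(ncn2Cc2ccc(OC)cc2)c(=O)[nH]1` is the unmeasured member, with a 4-methoxybenzyl on that nitrogen.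

For compound 1 this assay reports only a limit, > 500 ug/mL, so no number is known there; the limit is noted as the limit of > 500 ug/mL in this assay, at which 1 of the 3 values shown sits. Compound 2 gives 250 ug/mL in this assay. Compound 3 gives 300 ug/mL in this assay. The two numbers sit within the usual scatter of each other, so compound 2 and compound 3 cannot be told apart; compound 2 simply sits at the lower of the two numbers, with the limit of compound 1 standing apart.

The change from compound 2 to compound 4 is 4-methoxybenzyl in place of 4-hydroxy-5-(hydroxymethyl)oxolan-2-yl on an aromatic nitrogen. Among the measured compounds shown here, no measured step bears on this change. The expectation for compound 4 is a modest step from compound 2 to compound 4 of a 1.4-fold higher number from compound 2 to compound 4 (0.15 log units; within the scatter), toward a weaker number, with a fair chance that only a limit is returned as for compound 1 at > 500 ug/mL. Compound 4 is estimated at 350 ug/mL, in the range 120 ug/mL to 900 ug/mL.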

Compound 4, half-maximal inhibitory concentration: > 500 ug/mL
Compound 4 was reported as a limit; the forecaster's own chance of this, stated with the estimate: 35%; at least 1.4-fold (0.15 log units) between middle value and limit.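

In this assay, 4-methoxybenzyl in place of 4-hydroxy-5-(hydroxymethyl)oxolan-2-yl on the aromatic nitrogen gives an at least 2.0-fold higher number from compound 2 to compound 4 (0.30 log units; that floor lies within the scatter). Going by these compounds, the true size of this step is unknown, and its floor alone does not establish a real loss at this position. The result for compound 4 is a limit, and compound 4 now stands with compound 1, so among the compounds shown only those with a sugar group on this nitrogen, compound 2 and compound 3, return a number: the limit of > 500 ug/mL in this assay, at which 2 of the 4 values shown sit.

The compounds shown leave open whether a plain benzyl, an aminoethyl or a carboxymethyl group on this nitrogen would return a number in this assay. Also open, on these data alone, is whether a longer chain on the shared core would bring a 4-methoxybenzyl compound within the measurable range.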